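Ethyl side chain extended to (benzyloxy)methyl on the shared core

The source may hold more compounds than are shown below. What is called first, only, known or untested is meant among the compounds shown, and "the series" means these compounds.

Of the compounds shown here, three have been measured in a functional assay on CHOK cells for antagonist activity at growth hormone secretagogue receptor type 1 (Homo sapiens), read by calcium flux; on this read-out higher numbers stand for weaker inhibition and lower numbers for stronger inhibition. Compound 1 `CCc1nc(N)nc(N)c1-c1ccc(NCc2ccc(S(C)(=O)=O)cc2)cc1` gives 12 nM; compound 2 `CCc1nc(N)nc(N)c1-c1ccc(NCc2ccc([N+](=O)[O-])cc2)cc1` gives 23 nM; compound 3 `CCc1nc(N)nc(N)c1-c1ccc(NCc2ccnc(Cl)c2)cc1` gives 220 nM. Compound 2 stands second highest of the three numbers: the step of a 1.9-fold higher number from compound 1 to compound 2 (0.28 log units; within the scatter) lies within the scatter, while the step of a 9.6-fold higher number from compound 2 to compound 3 (0.98 log units; beyond the scatter) lies beyond it.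

Compound 4 `Nc1nc(N)c(-c2ccc(NCc3ccc([N+](=O)[O-])cc3)cc2)c(COCc2ccccc2)n1` is not yet measured. It differs from compound 2 by benzyloxy in place of methyl on a saturated chain carbon bound to an aromatic carbon; cut one bond further out, the change reads ethyl to (benzyloxy)methyl. Both measured steps concern the group on the saturated chain carbon bound to the nitrogen on the aromatic ring, not the chain on the core, so neither bears directly on this change. Going by the values given here, the series gives no step at this position; the expectation therefore rests on the value of compound 2 alone, with a wide range. For compound 4 a number near that of compound 2 is expected, with the step of a 1.7-fold higher number from compound 2 to compound 4 (0.24 log units; within the scatter) not expected to exceed the scatter with confidence. The estimate for compound 4 in this assay is 40 nM, with a range of 10 nM to 160 nM.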

Compound 4, half-maximal inhibitory concentration: 5.8 nM
The estimate for compound 4 lay 6.9-fold (0.84 log units) above the measured number; measured number outside the range, below it.
By their numbers in this assay, from the lowest: compound 4; then compounds 1 and 2 (each within the scatter of the next); then compound 3.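

Going by these compounds alone, the chain on the core, which the earlier steps did not touch, accepts a much larger group: in this assay, ethyl to (benzyloxy)methyl gives a 4.0-fold lower number from compound 2 to compound 4 (0.60 log units; beyond the scatter). In this one pair, the saturated chain carbon bound to an aromatic carbon is therefore not limited to a small alkyl group, and the added benzyloxy, with its six-membered aromatic ring of carbon only and its hydrogen-bond acceptor, comes with stronger inhibition rather than a loss. No measurement shown here accounts for the gain.

Still open, going by these compounds, is whether the oxygen or the aromatic ring of the benzyloxy carries the step, which a methoxymethyl or a 3-phenylpropyl group on the core would separate. Also open, on these data alone, is whether the same gain appears with methylsulfonyl in place of nitro.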